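Swapping One Side Chain on a Measured Compound

The compounds below may be only part of what the source reports. "The series", "measured", "known", "first", "only" and "open" are said of these compounds alone.

Values from a physicochemical assay for lipophilicity (a lower number here means a more polar compound, a higher number a more lipophilic compound), so far:
- Compound 1 `CCNC(=O)Nc1ccc(-c2nccc([C@]34CCOC[C@H]3C4)n2)cc1` gives 3.9
- Compound 2 `CNCC(=O)Nc1ccc(-c2nc(C(C)(C)S(C)(=O)=O)cc([C@]34CCOC[C@H]3C4)n2)cc1` gives 4.3

Compound 2 stands highest of the two at 4.3 and compound 1 lies lower at 3.9 by more than the usual scatter of repeat measurements.

Compound 3 `CCNC(=O)Nc1ccc(-c2nc(C(C)(C)S(C)(=O)=O)cc([C@]34CCOC[C@H]3C4)n2)cc1` has not yet been measured. It holds the same atoms as compound 2, joined differently (ethylamino in place of (methylamino)methyl on a carbonyl carbon), with ethylamino in place of (methylamino)methyl on a carbonyl carbon. Within the data shown here, no measured pair of compounds shows this exchange, so the data offer no direct guide to its size. The closest anchor is compound 2 at 4.3 and the estimate starts from that number. The expected change in this assay is small and stays within the scatter (a number 0.10 log units higher from compound 2 to compound 3 (within the scatter)). Two measured compounds are a thin basis, so the range is kept wide. Compound 3 is expected at 4.4 within an estimated range (3.9 to 4.9).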

Compound 3, partition coefficient: 4.7
The estimate for compound 3 lay 0.30 log units below the measured number; low and high end bracket the measured number.
By their numbers in this assay, from the lowest: compound 1; then compound 2; then compound 3.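

In this assay, putting ethylamino in place of (methylamino)methyl on a carbonyl carbon gives a number 0.40 log units higher from compound 2 to compound 3 (beyond the scatter) and leaves the heavy-atom count unchanged, so this position responds to how the same atoms are joined and not only to which atoms are present. The second exchange, 1-methyl-1-(methylsulfonyl)ethyl in place of hydrogen on an aromatic carbon, gives a number 0.80 log units higher from compound 1 to compound 3 (beyond the scatter) while the ethylcarbamoyl side chain stays the same, so this substituent can now be read on its own, which the earlier pair of compounds did not allow. Nothing available here explains why either exchange moves the number in this direction.

Going by these compounds, each exchange is seen only once, on a single background, so it remains open whether either step would keep its size and direction on a different compound. On these data alone, it also remains open how a longer chain such as propylamino or a carboxylic acid would read on that carbonyl carbon, and how a simple methyl group would compare with 1-methyl-1-(methylsulfonyl)ethyl on the aromatic carbon.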